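Adding a second chloro to the benzyl ring of compound 3

The compounds below may be only part of what the source reports. "The series", "measured", "known", "first", "only" and "open" are said of these compounds alone.

Measured so far:
compound 1 `O=[N+]([O-])c1cc(C(F)(F)F)cc([N+](=O)[O-])c1Oc1ccc(Cl)cc1/C=N\OCc1ccccc1`: 1220 nM
compound 2 `O=[N+]([O-])c1cc(C(F)(F)F)cc([N+](=O)[O-])c1Oc1ccc(Cl)cc1/C=N\OCc1ccccc1F`: 1110 nM
compound 3 `O=[N+]([O-])c1cc(C(F)(F)F)cc([N+](=O)[O-])c1Oc1ccc(Cl)cc1/C=N\OCc1ccccc1Cl`: 3950 nM

In a functional assay on MCF7 cells (Homo sapiens) for antiproliferative activity, read by MTT assay, with a stated time of 48 h (on this read-out higher numbers stand for weaker inhibition and lower numbers for stronger inhibition), compound 3 gives 3950 nM, the highest number of the three, which makes it the weakest inhibitor in this small set. The gaps are a 3.2-fold higher number from compound 1 to compound 3 (0.51 log units; beyond the scatter) and a 3.6-fold higher number from compound 2 to compound 3 (0.55 log units; beyond the scatter), whereas the remaining pair differs only by a 1.1-fold lower number from compound 1 to compound 2 (0.04 log units; within the scatter).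

Compound 4 `O=[N+]([O-])c1cc(C(F)(F)F)cc([N+](=O)[O-])c1Oc1ccc(Cl)cc1/C=N\OCc1ccc(Cl)cc1Cl` departs from compound 3 by one change, (chloro in place of hydrogen on an aromatic carbon), a chloro in place of hydrogen on an aromatic carbon that turns 2-chlorobenzyl into 2,4-dichlorobenzyl.

Among the compounds with values here, the nearest precedent is the same kind of exchange, a 3.2-fold higher number from compound 1 to compound 3 (0.51 log units; beyond the scatter), a modest rise. That step, however, produced the 2-chlorobenzyl group and so concerns another carbon of the ring. The fluoro step, a 1.1-fold lower number from compound 1 to compound 2 (0.04 log units; within the scatter), gives no direction. Within the data shown here, no measured step covers this carbon, so a slight upward lean is expected, but no shift beyond the scatter.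

The expected step is a 1.1-fold higher number from compound 3 to compound 4 (0.06 log units; within the scatter). For compound 4 the estimated value is 4500 nM, with an expected range of 1600 nM to 12000 nM.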

Compound 4, half-maximal inhibitory concentration: 1140 nM
Compound 4: the middle estimate sits 3.9-fold (0.60 log units) above what was measured; the whole stated range lies above it.
By their numbers in this assay, from the lowest: compounds 2, 4 and 1 (each within the scatter of the next); then compound 3.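

In this assay chloro in place of hydrogen on this aromatic carbon, meta to a chloro group and para to a large group, gives a 3.5-fold lower number from compound 3 to compound 4 (0.54 log units; beyond the scatter) and so runs opposite to a 3.2-fold higher number from compound 1 to compound 3 (0.51 log units; beyond the scatter) on another carbon of the same ring. The 2,4-dichlorobenzyl group therefore does not add to the rise seen with 2-chlorobenzyl, and the series returns to the level of the other benzyl groups, with a 1.1-fold lower number from compound 1 to compound 4 (0.03 log units; within the scatter) and a 1.0-fold higher number from compound 2 to compound 4 (0.01 log units; within the scatter) both within the scatter. Nothing available accounts for this reversal.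

Open, from the compounds shown here alone, is whether chloro on this carbon gives the same result without the 2-chloro group. Also open, going by these compounds, is how a methoxy group, an amine or a carboxylic acid on this carbon would read in this assay as a replacement for the chloro.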